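Swapping the para methoxy for chloro on the shared core

A few compounds are considered here, and "the series" means these few. Any claim that something is new, unique, unknown or untested is made for them only; others in the source may bear on it.

Compound 2 `COc1ccc(-c2nn3cc(-c4cccc(N)c4)nc3s2)cc1` stands at the limit of a functional assay on L1210 cells (Mus musculus) for inhibition, read by cell counting, with a stated time of 2 days; a lower number here means a stronger inhibitor, a higher number a weaker inhibitor: compound 2 gives >= 250000 nM, which is a limit of the assay and not a number. This is the point where the limit of >= 250000 nM in this assay, at which 1 of the 3 values shown sits, sits. Its closest neighbour, compound 1 `CCOc1ccc(-c2nn3cc(-c4cccc(N)c4)nc3s2)cc1`, gives 155000 nM in this assay, and the step of an at least 1.6-fold higher number from compound 1 to compound 2 (0.20 log units; that floor lies within the scatter) stays within the scatter. Compound 3 `C=C(Br)C(=O)Nc1cccc(-c2cn3nc(-c4ccc(OC)cc4)sc3n2)c1`, carrying a (1-bromoethenyl)carbonyl on the aniline nitrogen, gives 940 nM, and the step of an at least 260-fold lower number from compound 2 to compound 3 (2.42 log units; beyond the scatter) is the only large movement among the measured compounds.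

Compound 4 `Nc1cccc(-c2cn3nc(-c4ccc(Cl)cc4)sc3n2)c1` differs from compound 2 in one place, (chloro in place of methoxy on an aromatic carbon). Neither measured step touches this position: the step from compound 1 to compound 2 alters the chain on the aryl ether oxygen, and the step from compound 2 to compound 3 alters the aniline nitrogen, which compound 4 keeps free. Among the measured compounds shown here, the only guidance is that a change at the ether side, ethoxy to methoxy, moved the number by no more than the scatter. The expectation for compound 4 is therefore a step of an at least 1.2-fold lower number from compound 2 to compound 4 (0.09 log units; that floor lies within the scatter) that stays near the present level, with a fair chance that this assay again reports only a limit. The estimated value for compound 4 in this assay is 200000 nM, within a range from 60000 nM to 600000 nM.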

Compound 4, half-maximal inhibitory concentration: >= 250000 nM
Compound 4: only a limit was reported (the forecaster's own chance of this, stated with the estimate: 45%); middle value at least 1.2-fold (0.09 log units) from the limit.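

With chloro in place of methoxy on the aromatic carbon and the aniline nitrogen still free, the result in this assay remains out of numerical reach: compound 4 gives >= 250000 nM, which is a limit of the assay and not a number. Compound 2 and compound 4 now stand at the same limit, and the step between them cannot be read: the limit of >= 250000 nM in this assay, at which 2 of the 4 values shown sit.

The only readable comparison for this position is an at least 1.6-fold higher number from compound 1 to compound 4 (0.20 log units; that floor lies within the scatter), with chloro in place of ethoxy, and it gives only a floor, so the position has shown no readable movement beyond the scatter with ethoxy, methoxy or chloro, while the one large step remains the change on the aniline nitrogen in compound 3.

The compounds shown leave open how far the two limits lie from the true values, and whether chloro in place of methoxy would matter on the (1-bromoethenyl)carbonyl amide of compound 3, where a number can be read. They also leave open what a carboxylic acid or a dimethylamino group would give at this position on the shared core.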